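The source may report more compounds than this note shows. Statements on the series, on what has been measured and on what is new or still open speak of the compounds shown alone.

In a functional assay on BMMC cells (Mus musculus, strain C57BL/6) for inhibition, with stated times of 5 days and 48 h (on this read-out lower numbers stand for stronger inhibition and higher numbers for weaker inhibition), compound 2 `C=C1CC[C@@H]2[C@](C)(CNCc3cccc(OC)c3)[C@H](O)CC[C@@]2(C)[C@@H]1/C=C/C1=CCOC1=O` gives 780 nM, and compound 1 `C=C1CC[C@@H]2[C@](C)(CNCc3ccc(C)cc3)[C@H](O)CC[C@@]2(C)[C@@H]1/C=C/C1=CCOC1=O` gives 740 nM, so compound 2 stands beside compound 1 within the scatter on the two numbers available. Among the measured compounds shown here, the one measured step, a 1.1-fold higher number from compound 1 to compound 2 (0.02 log units; within the scatter), concerns an exchange of aryl groups on the same chain carbon. Compound 3 `C=C1CC[C@@H]2[C@](C)(CNCc3ccc(O)c(O)c3)[C@H](O)CC[C@@]2(C)[C@@H]1/C=C/C1=CCOC1=O` differs from compound 2 by 3,4-dihydroxyphenyl in place of 3-methoxyphenyl on a saturated chain carbon bound to an amine nitrogen. For the measured compounds named here, no measured step involves an aryl group bearing hydroxyls, so no step beyond the scatter is expected, a 1.2-fold higher number from compound 2 to compound 3 (0.06 log units; within the scatter). Compound 3 is therefore estimated at 900 nM, with a range from 300 nM to 2700 nM.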

Compound 3, half-maximal inhibitory concentration: 9440 nM
Compound 3: middle estimate off by 10-fold (1.02 log units), on the low side, and the stated range ends below it.
By their numbers in this assay, from the lowest: compounds 1 and 2 (each within the scatter of the next); then compound 3.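

In this assay, the aryl group on a saturated chain carbon bound to an amine nitrogen is not freely exchangeable. 3,4-Dihydroxyphenyl in place of 3-methoxyphenyl gives a 12-fold higher number from compound 2 to compound 3 (1.08 log units; beyond the scatter) and in place of 4-methylphenyl gives a 13-fold higher number from compound 1 to compound 3 (1.11 log units; beyond the scatter) while the earlier aryl exchange stayed within the scatter. Nothing available explains this loss.

The compounds shown leave open whether a single hydroxyl, as in 4-hydroxyphenyl, would give a step of this size. They also leave open whether 3,4-dimethoxyphenyl would stand with compound 2 or with compound 3.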